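A few compounds are considered here, and "the series" means these few. Any claim that something is new, unique, unknown or untested is made for them only; others in the source may bear on it.

Compound 1 `CCCCC(O)c1cccc(NC(=O)CCCl)c1` gives > 100000 nM in a functional assay on MCF7 cells (Homo sapiens) for antiproliferative activity, with a stated time of 48 h (a higher number here means a weaker inhibitor, a lower number a stronger inhibitor), which is a limit of the assay. Compound 2 `CCCCC(OC)c1cccc(NC(=O)CCCl)c1` gives > 100000 nM in this assay, again a limit. Compound 3 `CCCCC(O)c1cccc(NC(=O)CCCCl)c1` gives > 100000 nM in this assay, also a limit.

Compound 2 differs from compound 1 by methyl in place of hydrogen on an oxygen on a saturated carbon. Compound 3 differs from compound 1 by chloromethyl in place of chloro on a saturated chain carbon, two bonds along the chain from a carbonyl carbon. Neither step is readable: a step that the two limits leave unreadable from compound 1 to compound 2 and a step that the two limits leave unreadable from compound 1 to compound 3, because of the limit of > 100000 nM in this assay, at which 3 of the 3 values shown sit. Compound 4 `CCCCC(OC)c1cccc(NC(=O)CCCCl)c1`, not yet measured, carries the same change relative to compound 3: methyl in place of hydrogen on an oxygen on a saturated carbon.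

Since the two changes are the same, compound 4 is expected to behave as compound 3 does in this assay, with an expected step that the limit leaves unreadable from compound 3 to compound 4 beside the unreadable a step that the two limits leave unreadable from compound 1 to compound 2. The estimate for compound 4 in this assay is therefore 150000 nM, between 60000 nM and 400000 nM.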

Compound 4, half-maximal inhibitory concentration: > 100000 nM
Compound 4 ended at the assay's limit; the forecaster's own chance of this, stated with the estimate: 85%; the middle value is on the limit's open side.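

Neither the step from compound 3 to compound 4 nor the step from compound 2 to compound 4 can be read: the limit of > 100000 nM in this assay, at which 4 of the 4 values shown sit. The compounds shown leave open whether hydroxy to methoxy, or chloro to chloromethyl, changes the activity at all.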